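A few compounds are considered here, and "the series" means these few. Any claim that something is new, unique, unknown or untested is made for them only; others in the source may bear on it.

Compound 1 `CC(CCc1nnn[nH]1)Cc1ccc(OCc2ccc3ccccc3n2)cc1`: 27 nM in a functional assay (lung) for inhibition, with Cavia porcellus as the target; on this read-out higher numbers stand for weaker inhibition and lower numbers for stronger inhibition.
Compound 2 `CC(CCCC(=O)O)c1cccc(OCc2ccc3ccccc3n2)c1`: 500 nM in this assay.

Compound 2 stands highest of the two numbers, and compound 1 lies well below it, beyond the scatter. Compound 3 `c1cc(OCCCc2nnn[nH]2)cc(OCc2ccc3ccccc3n2)c1` is not yet measured. It differs from compound 2 by 3-(1H-tetrazol-5-yl)propoxy in place of 4-carboxy-1-methylbutyl on an aromatic carbon. Compound 1 also carries a tetrazole on its side chain and gives 27 nM in this assay. The step of an 8.3-fold lower number from compound 2 to compound 3 (0.92 log units; beyond the scatter) is therefore expected to be a fall, beyond the scatter. For compound 3 an estimate of 60 nM is given, within a range from 15 nM to 250 nM.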

Compound 3, half-maximal inhibitory concentration: 79 nM
For compound 3 the middle estimate is 1.3-fold (0.12 log units) below the measured one, within the range that was stated.
By their numbers in this assay, from the lowest: compound 1; then compound 3; then compound 2.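

In this assay there is a 6.3-fold lower number from compound 2 to compound 3 (0.80 log units; beyond the scatter) when 3-(1H-tetrazol-5-yl)propoxy replaces 4-carboxy-1-methylbutyl on an aromatic carbon, so a tetrazole-bearing chain is tolerated at this position, meta to a large group. The change alters the chain and its end group together, so the step cannot be assigned to either alone. Nothing measured here accounts for the step. Still open, from the compounds shown here alone, is whether a carboxylic acid on the same propoxy chain would give a similar number, and whether a longer chain carrying the tetrazole would shift it.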